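A Triazole Added to a Compound Without a Measured Potency

A few compounds are considered here, and "the series" means these few. Any claim that something is new, unique, unknown or untested is made for them only; others in the source may bear on it.

Compound 1 `COc1c(OC(C)C)cc2occ(-c3csc4ccccc34)c(=O)c2c1OC(C)C` was tested in a functional assay on KB cells (Homo sapiens) for antiproliferative activity, read by sulforhodamine B assay, with a stated time of 72 h (a lower number here means a stronger inhibitor, a higher number a weaker inhibitor), and gives > 10000 nM as a limit and not as a number. Compound 2 `COc1c(OC(C)C)cc2occ(-c3csc4ccccc34)c(=O)c2c1O` gives > 10000 nM in this assay as a limit too. Compound 3 `COc1c(OC(C)C)cc2occ(-c3ccccc3)c(=O)c2c1OC(C)C` likewise gives > 10000 nM as a limit. Compound 1 therefore stands with the others at the limit of > 10000 nM in this assay, at which 3 of the 3 values shown sit, and none of the three has a number that could rank it.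

Compound 4 `COc1c(OC(C)C)cc2oc(-n3cncn3)c(-c3csc4ccccc34)c(=O)c2c1OC(C)C` keeps the core of compound 1 and carries a single change: 1H-1,2,4-triazol-1-yl in place of hydrogen on an aromatic carbon with the new group next to the ring oxygen and ortho to a 1-benzothiophen-3-yl group. Two measured steps lie nearest, namely a step that the two limits leave unreadable from compound 1 to compound 2 and also a step that the two limits leave unreadable from compound 1 to compound 3 and neither touches this carbon or offers a size to carry over. Among the compounds with values here, the only anchor is therefore the limit of the parent, so no measured step supports a gain in this assay and no direction is favoured. The expected step is a number no higher from compound 1 to compound 4 (the limit leaves the size open) and it is expected to stay close to that limit. Compound 4 is estimated at 10000 nM with an expected range from 3000 nM to 30000 nM and will quite likely be reported as a limit again.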

Compound 4, half-maximal inhibitory concentration: > 10000 nM
Compound 4: only a limit was reported; the forecaster's own chance of this, stated with the estimate: 75%; the middle value lies on the limit itself.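

In this assay compound 4 gives > 10000 nM, which is a limit and not a number. Within the data shown here, compound 1 is also held only by a limit, so no step from compound 1 to compound 4 can be read. The compounds shown leave open whether 1H-1,2,4-triazol-1-yl changes potency at all, and how any of them ranks against another, since all rest at one point: the limit of > 10000 nM in this assay, at which 4 of the 4 values shown sit.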